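Clearance of a Pyridone Series in Rat Hepatocytes

The source may hold more compounds than are shown below. What is called first, only, known or untested is meant among the compounds shown, and "the series" means these compounds.

Measured compounds:
compound 1, `CN(C)C(=O)CN1CCC(c2cc3c(-c4ccc(=O)n(CCC5CCOCC5)c4)ccnc3[nH]2)CC1` — 14 uL/min
compound 2, `COc1cc(F)ccc1-c1ccnc2[nH]c(C3CCOCC3)cc12` — 97 uL/min

In an ADME assay on cells (Hepatocyte, Rattus norvegicus) for metabolic stability (on this read-out lower numbers stand for slow clearance and higher numbers for fast clearance), compound 1 gives 14 uL/min, the lowest of the two numbers recorded. Its nearest neighbour is compound 2, a smaller compound built on a different core, which gives 97 uL/min; the gap between the two values lies beyond the scatter of this assay. Among the compounds with values here, no pair of measured compounds differs in a single place, so no measured step is available to anchor a prediction.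

The unmeasured compound 3, `CN(C)C(=O)CN1CCC(c2cc3c(-c4ccc(=O)n(C5CCC5)c4)ccnc3[nH]2)CC1`, shares the core of compound 1 and differs from it in one place: cyclobutyl in place of 2-(oxan-4-yl)ethyl on an aromatic nitrogen. Within the data shown here, the leaving group is larger and carries one hydrogen-bond acceptor, while the entering group is a small ring of carbon only, but there is no measured pair that tells how such a swap moves the number in this assay. The step from compound 1 to compound 3 is therefore expected to be small, a 1.3-fold higher number from compound 1 to compound 3 (0.11 log units; within the scatter), with no direction that can be justified beyond the scatter. Compound 3 is estimated to give 18 uL/min in this assay, within a range from 8 uL/min to 45 uL/min.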

Compound 3, intrinsic clearance in a liver preparation (reported as CLH), per the amount of preparation that the assay uses: 5.8 uL/min
Estimate against measurement, compound 3: 3.1-fold (0.49 log units) above; measured number outside the range, below it.
By their numbers in this assay, from the lowest: compound 3; then compound 1; then compound 2.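

At this aromatic nitrogen of the shared core, the substituent does move the number in this assay: cyclobutyl in place of 2-(oxan-4-yl)ethyl gives a 2.4-fold lower number from compound 1 to compound 3 (0.38 log units; beyond the scatter). Within the data shown here, this is the first measured step between compounds that differ in one place, and it shows that the low number of compound 1 does not depend on keeping 2-(oxan-4-yl)ethyl here, as the smaller all-carbon ring without a hydrogen-bond acceptor goes with a lower number still. Nothing measured alongside these values accounts for the step.

As far as these compounds go, a single swap cannot separate the part played by the size of the group from that of its ring oxygen or its two-carbon link, so it remains open how an oxan-4-yl ring set directly on the nitrogen, a 2-cyclobutylethyl chain or a cyclopentyl ring would read in this assay. From the compounds shown here alone, it also remains open whether the step would hold if a carboxylic acid stood in place of the dimethylamide at the far end of the molecule.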